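Swapping the fused heteroaryl on a bis-benzyloxy furanone core

The source may hold more compounds than are shown below. What is called first, only, known or untested is meant among the compounds shown, and "the series" means these compounds.

In a functional assay on MIA PaCa-2 cells (Homo sapiens) for antiproliferative activity, read by MTT assay, with a stated time of 72 h (a higher number here means a weaker inhibitor, a lower number a stronger inhibitor), compound 1 `O=C1O/C(=C\Cn2cnc3c(F)nc(F)c(Cl)c32)C(OCc2ccccc2)=C1OCc1ccccc1` gives 78000 nM. For compound 2 `O=C1O/C(=C\Cn2cnc3cc[nH]c3c2=O)C(OCc2ccccc2)=C1OCc1ccccc1` the same measurement reports only a limit, > 100000 nM. The step of an at least 1.2-fold higher number from compound 1 to compound 2 (0.10 log units; that floor lies within the scatter) is therefore bounded from below only because the limit of > 100000 nM in this assay, at which 1 of the 2 values shown sits, marks where one of the two shown values sits. Compound 3 `O=C1O/C(=C\Cn2cnc3cncc(Br)c32)C(OCc2ccccc2)=C1OCc1ccccc1` has not yet been measured in this assay. It differs from compound 2 by a group of 10 heavy atoms (6 carbon, 3 nitrogen, 1 bromine; one five-membered aromatic ring with 2 hetero atoms, one six-membered aromatic ring with 1 hetero atom) in place of a group of 10 heavy atoms (6 carbon, 3 nitrogen, 1 oxygen; one five-membered aromatic ring with 1 hetero atom, one six-membered aromatic ring with 2 hetero atoms), on a saturated chain carbon bound to a double-bonded chain carbon. For the measured compounds named here, the change largely restores the ring pattern of compound 1, with a bromine in place of the fluorines and chlorine, so the single measured step, read backwards, suggests a number at or under the limit of compound 2 and near the value of compound 1. Compound 3 is therefore expected to give 80000 nM in this assay, within 30000 nM to 200000 nM. This estimate is expected to mean a step of an at least 1.2-fold lower number from compound 2 to compound 3 (0.09 log units; that floor lies within the scatter).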

Compound 3, half-maximal inhibitory concentration: 22600 nM
Beside the measured number, compound 3's estimate is 3.5-fold (0.55 log units) above it, and the stated range ends above it.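

In this assay, the group on a saturated chain carbon bound to a double-bonded chain carbon now moves the number beyond the scatter: the group with one bromine, in place of the group with two fluorines and one chlorine, gives a 3.5-fold lower number from compound 1 to compound 3 (0.54 log units; beyond the scatter). Set against the oxygen-containing group of compound 2, the same bromine group gives an at least 4.4-fold lower number from compound 2 to compound 3 (0.64 log units; beyond the scatter). Compound 2 has only a limit, so this step is a floor and its full size cannot be read: the limit of > 100000 nM in this assay, at which 1 of the 3 values shown sits.

The compounds shown leave open whether the bromine itself accounts for the lower number, or whether a single chlorine, a methyl or an amine in its place would give a similar value. They also leave open how the number would respond if the two benzyloxy groups on the shared core were replaced by methoxy groups.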